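A few compounds are considered here, and "the series" means these few. Any claim that something is new, unique, unknown or untested is made for them only; others in the source may bear on it.

Compound 1 `Cc1nc2c(OCc3ccccc3)cccn2c1N`: 74%
Compound 2 `Cc1nc2c(OCc3ccc(Cl)cc3)cccn2c1N`: 81%
Compound 3 `Cc1nc2c(OCc3cccs3)cccn2c1N`: 80%

In a functional assay on the whole organism with Canis familiaris (Canis lupus familiaris) as the target, at a dose of 4 mg/kg by the oral route (a higher number here means a stronger effect of the compound at the dose given, a lower number a weaker effect), compound 1 holds the smallest of the three numbers, yet the two steps away from it, a number 7 percentage points higher from compound 1 to compound 2 (within the scatter) and a number 6 percentage points higher from compound 1 to compound 3 (within the scatter), both lie within the scatter, so the three compounds cannot be told apart. Compound 4 `Cc1ccn2c(N)c(C)nc2c1OCc1ccccc1` differs from compound 1 by methyl in place of hydrogen on an aromatic carbon. Neither measured step touches the shared core in this way; both alter the benzyl side and both stayed within the scatter. The data therefore give no direct guide, and no step beyond the scatter is expected. Compound 4 is estimated to give 74% (range 55% to 88%), which would be a step of no change at the digits printed from compound 1 to compound 4 (within the scatter).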

Compound 4, a percentage reported as inhibition, in the whole organism at one dose (the size of the read-out at that dose, not a potency): 36%
Compound 4: middle estimate off by 38 percentage points, on the high side, outside the stated range (below it).
By their numbers in this assay, from the lowest: compound 4; then compounds 1, 3 and 2 (each within the scatter of the next).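

In this assay, among the compounds shown here, methyl in place of hydrogen on the aromatic carbon ortho to the group of 8 heavy atoms gives a number 38 percentage points lower from compound 1 to compound 4 (beyond the scatter) and is the only step here beyond the scatter. The two earlier steps changed only the benzyl side, so this one shows that the read-out can respond strongly to a single methyl on the shared core. Nothing measured explains this drop.

Going by these compounds, it remains open whether fluoro, methoxy or an amine at this place would lower the number as well. On these data alone, it is also open whether methyl here would do the same alongside the 4-chlorobenzyl or thiophen-2-yl side.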